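Allyl to 4-bromobenzyl: a step from an assay limit

The source may hold more compounds than are shown below. What is called first, only, known or untested is meant among the compounds shown, and "the series" means these compounds.

In a toxicity assay on GES1 cells (Homo sapiens) for inhibition, read by MTT assay, with a stated time of 72 h (on this read-out lower numbers stand for stronger inhibition and higher numbers for weaker inhibition), compound 1 `Cc1cc(N2CC[C@@H](C)[C@@H](N(C)c3ncnc4[nH]ccc34)C2)n2nc(SCC3CCCCC3)nc2n1` gives 98200 nM. Compound 2 `C=CCSc1nc2nc(C)cc(N3CC[C@@H](C)[C@@H](N(C)c4ncnc5[nH]ccc45)C3)n2n1` gives no number but a limit of the assay, > 100000 nM, and this is the limit of > 100000 nM in this assay, at which 1 of the 2 values shown sits. The next compound, compound 3 `Cc1cc(N2CC[C@@H](C)[C@@H](N(C)c3ncnc4[nH]ccc34)C2)n2nc(SCc3ccc(Br)cc3)nc2n1`, differs from compound 2 at one place: 4-bromophenyl in place of vinyl on a saturated chain carbon bound to a sulfur. In words, 4-bromophenyl stands in place of vinyl on a saturated chain carbon bound to a sulfur.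

Within the data shown here, only one measured step bears on this change. It put vinyl in place of cyclohexyl at that same carbon, and it reads an at least 1.0-fold higher number from compound 1 to compound 2 (0.00 log units; that floor lies within the scatter). From the compounds shown here alone, this step is bounded on one side only, so its true size remains unknown, and it involved a different group. It offers no support for a large move in this assay when vinyl leaves again. Any shift is expected to be small, towards a lower number if it appears, and probably not beyond the scatter.

The expected step is an at least 1.2-fold lower number from compound 2 to compound 3 (0.09 log units; that floor lies within the scatter). For compound 3 the estimated value is 80000 nM, with an expected range from 30000 nM to 100000 nM.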

Compound 3, half-maximal inhibitory concentration: 55600 nM
For compound 3 the middle estimate is 1.4-fold (0.16 log units) above the measured one; the measured number falls inside the stated range.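

With 4-bromophenyl on the saturated chain carbon bound to a sulfur, the series now holds an aromatic ring at this place, and in this assay replacing cyclohexyl at the same carbon gives a 1.8-fold lower number from compound 1 to compound 3 (0.25 log units; within the scatter), so between these two compounds a saturated ring and a brominated aromatic ring are not told apart by this read-out. Replacing vinyl gives an at least 1.7-fold lower number from compound 2 to compound 3 (0.25 log units; that floor lies within the scatter), which is a floor and not the size of the step, and this floor also stays inside the usual scatter. Compound 2 itself remains a limit of the assay, > 100000 nM, and not a number: the limit of > 100000 nM in this assay, at which 1 of the 3 values shown sits.

The compounds shown leave open whether the bromine plays any part in the value of compound 3, and how a plain benzyl or a 4-methoxybenzyl would read on this sulfur. Also open, from the compounds shown here alone, are how far the true value of compound 2 lies from that of compound 3, and whether an amine or a carboxylic acid carried on this chain would move the read-out beyond the scatter.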